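Replacing bromo with methyl on compound 3

A few compounds are considered here, and "the series" means these few. Any claim that something is new, unique, unknown or untested is made for them only; others in the source may bear on it.

- Compound 1 `COc1ccc(-c2nnc(NC(=O)/C=C/c3ccc(F)cc3)s2)cc1` gives 0.75 ug/mL
- Compound 2 `Cc1ccc(/C=C/C(=O)Nc2nnc(-c3ccc(C)cc3)s2)cc1` gives 1.08 ug/mL
- Compound 3 `O=C(/C=C/c1ccc(F)cc1)Nc1nnc(-c2ccc(Br)cc2)s1` gives 2.83 ug/mL

In a functional assay on A549 cells (Homo sapiens) for antiproliferative activity, read by MTT assay, with a stated time of 48 h (a lower number here means a stronger inhibitor, a higher number a weaker inhibitor), compound 3 gives 2.83 ug/mL as the highest number of the three, which makes it the weakest inhibitor measured so far. Compound 4 `Cc1ccc(-c2nnc(NC(=O)/C=C/c3ccc(F)cc3)s2)cc1` differs from compound 3 in a single place, where 4-bromophenyl becomes 4-methylphenyl: methyl in place of bromo on an aromatic carbon describes the swap, which is methyl in place of bromo on an aromatic carbon.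

Going by the values given here, one measured step touches this same place. Putting bromo in place of methoxy gave a 3.8-fold higher number from compound 1 to compound 3 (0.58 log units; beyond the scatter) and counts as modest. Leaving bromo could therefore win back part of that loss, although methyl is not methoxy and no measured pair shows this exact swap. Among the compounds with values here, compound 2 gives 1.08 ug/mL and is the only measured compound carrying 4-methylphenyl, but it also differs from compound 4 elsewhere, so it offers only partial support.

In this assay a modest move towards a lower number is therefore expected, and it is estimated as a 2.4-fold lower number from compound 3 to compound 4 (0.37 log units; beyond the scatter) overall. The expected result for compound 4 is 1.2 ug/mL as the middle estimate, within a range from 0.6 ug/mL to 2.4 ug/mL as expected bounds.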

Compound 4, half-maximal inhibitory concentration: 1.23 ug/mL
The estimate for compound 4 lay 1.0-fold (0.01 log units) below the measured number; the measured number falls inside the stated range.
By their numbers in this assay, from the lowest: compounds 1, 2 and 4 (each within the scatter of the next); then compound 3.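

In this assay, the direct swap at this place gives a 2.3-fold lower number from compound 3 to compound 4 (0.36 log units; beyond the scatter), so the loss seen earlier with bromo (where a 3.8-fold higher number from compound 1 to compound 3 (0.58 log units; beyond the scatter)) is not tied to methoxy alone. Methyl and methoxy at this place cannot be told apart (a 1.6-fold higher number from compound 1 to compound 4 (0.21 log units; within the scatter)), which leaves bromo as the one group of the three that stands apart here. With 4-methylphenyl held fixed, fluoro in place of methyl on the other aromatic ring gives a 1.1-fold higher number from compound 2 to compound 4 (0.06 log units; within the scatter), so that second place shows no separable difference for this pair.

Nothing measured here explains why bromo stands apart from methyl and methoxy. As far as these compounds go, whether chloro, an amine or a carboxylic acid on the same ring would sit with bromo or with methyl and methoxy remains open, as does the reading of the other ring with any group beyond fluoro and methyl.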